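The source may report more compounds than this note shows. Statements on the series, on what has been measured and on what is new or still open speak of the compounds shown alone.

Compound 3 `CSc1ccc(S(=O)(=O)NC(=O)Nc2ccc(Cl)cc2)s1` gives 62% in a functional assay on the whole organism (6C3HED cells, Mus musculus) for inhibition, at a dose of 300 mg/kg by the oral route (on this read-out lower numbers stand for less inhibition and higher numbers for more inhibition at the one dose given (going by the name of the read-out)), the lowest of the three numbers seen so far. Its nearest neighbour is compound 1 `O=C(Nc1ccc(Cl)cc1)NS(=O)(=O)c1cccs1`, which gives 66%; the step of a number 4 percentage points lower from compound 1 to compound 3 (within the scatter) lies within the scatter. Compound 2 `COc1ccc(S(=O)(=O)NC(=O)Nc2ccc(Cl)cc2)s1` gives 100%, and the step of a number 38 percentage points lower from compound 2 to compound 3 (beyond the scatter) is a large one. Compound 4 `CCc1ccc(S(=O)(=O)NC(=O)Nc2ccc(Cl)cc2)o1` differs from compound 3 by 5-ethylfuran-2-yl in place of 5-(methylsulfanyl)thiophen-2-yl on a sulfonyl sulfur. Among the measured compounds shown here, none of the measured steps covers this exchange: the steps of a number 34 percentage points higher from compound 1 to compound 2 (beyond the scatter) and a number 4 percentage points lower from compound 1 to compound 3 (within the scatter) only vary the group on a ring that itself stays the same, while here both the ring and its group are exchanged. The expectation for compound 4 is therefore wide, with a step of a number 3 percentage points higher from compound 3 to compound 4 (within the scatter) expected. Compound 4 is estimated at 65%, within 35% to 95%.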

Compound 4, a percentage reported as inhibition, in the whole organism at one dose (the size of the read-out at that dose, not a potency): 80%
Estimate against measurement, compound 4: 15 percentage points below; measured number inside the range.
By their numbers in this assay, from the lowest: compounds 3 and 1 (each within the scatter of the next); then compound 4; then compound 2.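

On the sulfonyl sulfur, in this assay, 5-ethylfuran-2-yl gives a step of a number 18 percentage points higher from compound 3 to compound 4 (beyond the scatter) and one of a number 14 percentage points higher from compound 1 to compound 4 (beyond the scatter), while the step of a number 20 percentage points lower from compound 2 to compound 4 (beyond the scatter) leaves it short of the 5-methoxythiophen-2-yl group. Among the compounds shown here, this position therefore accepts an exchange of the ring together with its group, which the earlier compounds, all sharing one ring, could not show. Nothing in the data explains these steps. Which part of the exchange, ring or group, carries the change stays open. So does how an amine or a longer chain on the furan would read.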